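Chloro in place of hydrogen on compound 3

This account rests on a few compounds, and the source may have more. Where it says the series, first, only, none or still open, it means among the compounds named here.

Measured compounds in a functional assay on KB cells (Homo sapiens) for inhibition, read by MTT assay, with a stated time of 24 h, tested at 1 ug/mL (on this read-out lower numbers stand for less inhibition of growth and higher numbers for more inhibition of growth at the one concentration tested), are as follows.
- compound 1 `O=C(CCCCC1CCSS1)Nc1ccccn1` gives "not active" (no number reported)
- compound 2 `O=C(CCCCC(S)CCS)Nc1ccc([N+](=O)[O-])cc1` gives 0.93%
- compound 3 `CC(=O)SCCC(CCCCC(=O)Nc1ccccc1)SC(C)=O` gives 1.68%

In this assay, going by the values given here, compound 3 (1.68%) lies within the usual scatter of compound 2 (0.93%), the only other compound with a number. Compound 1 offers no number for comparison.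

Compound 4 `CC(=O)SCCC(CCCCC(=O)Nc1ccc(Cl)cc1)SC(C)=O` is compound 3 with chloro in place of hydrogen on an aromatic carbon, para to a large group (chloro in place of hydrogen on an aromatic carbon). Among the compounds with values here, no measured pair shows a change of this kind, so the expectation rests only on the low readings of compound 2 (0.93%) and compound 3 (1.68%). In this assay a small step toward more inhibition of growth is expected, possibly none beyond the scatter. The expected change is (a number 1.3 percentage points higher from compound 3 to compound 4 (within the scatter)) and remains only an estimate. Compound 4 is estimated at 3% with an expected range from 0% to 15% for this single concentration.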

Compound 4, percent growth inhibition at one concentration: 14.8%
Estimate against measurement, compound 4: 11.8 percentage points below; low and high end bracket the measured number.
By their numbers in this assay, from the lowest: compounds 2 and 3 (each within the scatter of the next); then compound 4.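

In this assay, going by these compounds alone, phenyl to 4-chlorophenyl gives a number 13.1 percentage points higher from compound 3 to compound 4 (beyond the scatter), the only step so far and one that clears the scatter. The earlier compounds shown here could not show this, as none of them forms a pair differing in one place; the aromatic carbon para to a large group now stands as a place where one added chlorine atom shifts the reading, though only modestly at the single concentration tested. Nothing measured here accounts for the step.

Whether the shift is particular to chloro remains open, as the compounds shown include no bromo, methoxy or amine at this place. Also open, from the compounds shown here alone, is whether chloro has the same effect with the free thiol groups of compound 2 or the ring of compound 1 in place of the acetylthio groups.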